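A few compounds are considered here, and "the series" means these few. Any claim that something is new, unique, unknown or untested is made for them only; others in the source may bear on it.

Measured so far:
compound 1 `CCc1ccccc1-c1cccc(COc2ccc([C@H](CC(=O)O)c3nccn3C)cc2)c1`, giving 48 nM in an assay on CHO cells for agonist activity at Free fatty acid receptor 1 (Homo sapiens), read by luminescence, with a stated time of 20 s, in the presence of a further agent that is not named here; a higher number here means that more compound is needed for the effect, a lower number that less compound is needed;
compound 2 `Cn1ccnc1[C@@H](CC(=O)O)c1ccc(OCc2cccc(-c3ccccc3S(C)(=O)=O)c2)cc1`, giving 23000 nM;
compound 3 `Cc1cc(Cl)ccc1-c1cccc(COc2ccc([C@H](CC(=O)O)c3nccn3C)cc2)c1C`, giving 240 nM.

Among these three, compound 2 stands at the highest number, so the most compound is needed for the effect. Compared with compound 3 its number is far higher, and the gap to compound 1 is wider still. For the measured compounds named here, only one single-point step among the measured compounds connects to compound 2: the change from compound 1 to compound 2, which is an ethyl replaced by a methylsulfonyl on an aromatic carbon, and it gave a 480-fold higher number from compound 1 to compound 2 (2.68 log units; beyond the scatter).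

Compound 4 `COc1ccccc1-c1cccc(COc2ccc([C@H](CC(=O)O)c3nccn3C)cc2)c1` differs from compound 2 in one place: methoxy in place of methylsulfonyl on an aromatic carbon. The change sits on an aromatic carbon of a six-membered aromatic ring of carbon only, ortho to a large group. It removes the very group whose entry, from compound 1 to compound 2, went with the large rise just described, and puts in its place a methoxy, which is a small group like the ethyl of compound 1. On that basis the expected step for compound 4 is a large fall, a 190-fold lower number from compound 2 to compound 4 (2.28 log units; beyond the scatter), back toward the region of compound 1 and compound 3. The estimate for compound 4 in this assay is 120 nM, within a range from 30 nM to 700 nM.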

Compound 4, half-maximal effective concentration: 410 nM
Compound 4: the middle estimate sits 3.4-fold (0.53 log units) below what was measured; the range from low to high includes it.
By their numbers in this assay, from the lowest: compound 1; then compounds 3 and 4 (each within the scatter of the next); then compound 2.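

Putting methoxy in place of methylsulfonyl at this position recovers most of what compound 2 lost: in this assay the change gives a 56-fold lower number from compound 2 to compound 4 (1.75 log units; beyond the scatter), so the steep loss goes with the methylsulfonyl group itself and not merely with the absence of ethyl. The recovery is only partial, since the change from ethyl to methoxy gives an 8.5-fold higher number from compound 1 to compound 4 (0.93 log units; beyond the scatter), which shows that the assay also separates these two groups, though by a much smaller step than the one seen with methylsulfonyl. Nothing shown here explains why the three groups give such different numbers at this position.

It remains open where groups such as methylthio, which keeps the sulfur of methylsulfonyl without its two oxygens, ethoxy, or a plain hydrogen would fall among these three, and so which feature of methylsulfonyl goes with the loss. Also open, as far as these compounds go, is whether methoxy and methylsulfonyl would give a similar gap at another place on this ring.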